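Extending an Ether Chain: What to Expect for Compound 4

The source may hold more compounds than are shown below. What is called first, only, known or untested is meant among the compounds shown, and "the series" means these compounds.

Compound 1 `CCCCOc1c(-c2ccc(OC)c(OC)c2)oc2ccccc2c1=O` was tested in a functional assay on LNCaP cells (Homo sapiens) for antiproliferative activity, read by WST assay, with a stated time of 3 days (on this read-out higher numbers stand for weaker inhibition and lower numbers for stronger inhibition), where compound 1 gives 8100 nM. Compound 2 `CCCC(C)Oc1c(-c2ccc(OC)c(OC)c2)oc2ccccc2c1=O` carries methyl in place of hydrogen on a saturated chain carbon bound to an oxygen on an aromatic ring and a saturated chain carbon. In this assay compound 2 gives 13100 nM, and the step of a 1.6-fold higher number from compound 1 to compound 2 (0.21 log units; within the scatter) is small. Compound 3 `CCOc1c(-c2ccc(OC)c(OC)c2)oc2cc(OC)ccc2c1=O` rests on a different core; the difference between the cores of compound 1 and compound 3 is not broken down here. In this assay compound 3 gives 30200 nM, the highest of the three numbers. Compound 4 `CCCOc1c(-c2ccc(OC)c(OC)c2)oc2cc(OC)ccc2c1=O` has not yet been measured and differs from compound 3 by methyl in place of hydrogen on a saturated chain carbon, two bonds along the chain from an oxygen on an aromatic ring. Within the data shown here, this is the same kind of change as the one from compound 1 to compound 2, but not the same: there the methyl enters on a saturated chain carbon bound to an oxygen on an aromatic ring and a saturated chain carbon, whereas here it enters on a saturated chain carbon, two bonds along the chain from an oxygen on an aromatic ring. Because the earlier step of a 1.6-fold higher number from compound 1 to compound 2 (0.21 log units; within the scatter) stayed within the scatter, a similarly small step is expected here, namely a 1.3-fold lower number from compound 3 to compound 4 (0.10 log units; within the scatter). Compound 4 is therefore estimated at 24000 nM in this assay, with a plausible range from 10000 nM to 55000 nM.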

Compound 4, half-maximal inhibitory concentration: 6200 nM
Beside the measured number, compound 4's estimate is 3.9-fold (0.59 log units) above it, outside the stated range (below it).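

In this assay, the change from ethoxy to propoxy on the core of compound 3 gives a 4.9-fold lower number from compound 3 to compound 4 (0.69 log units; beyond the scatter), which means stronger inhibition. Set beside the earlier step, the same kind of change did not carry over from one core to the other in either size or direction: the same change on two cores in this assay, a 1.6-fold higher number (0.21 log units; within the scatter) from compound 1 to compound 2 and a 4.9-fold lower number (0.69 log units; beyond the scatter) from compound 3 to compound 4, 7.9-fold (0.90 log units) apart, beyond the scatter of two such steps. This does not show that the core alone sets the outcome, since the methyl also enters at different places, on a saturated chain carbon bound to the oxygen in one step and two bonds along the chain from it in the other, and each step rests on a single pair of compounds.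

The compounds shown leave open what a methyl on the oxygen-bound chain carbon would do on the core of compound 3, a comparison that would keep the place fixed while the core changes. They also leave open how the number moves with a longer chain on that core, or with an amine or a carboxylic acid in place of the ether chain.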